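The source may report more compounds than this note shows. Statements on the series, on what has been measured and on what is new or still open speak of the compounds shown alone.

Compound 1 `C[C@@H](NC(=O)c1ccc(C#Cc2ccccc2)cn1)C(C)(C)O` gives 60.9% in a functional assay on HEK293 cells for positive allosteric modulation of metabotropic glutamate receptor 5 (Rattus norvegicus), read by fluorescence and calcium flux; on this read-out lower numbers stand for smaller maximal responses and higher numbers for larger maximal responses.
Compound 2 `C[C@@H](NC(=O)c1ccc(C#Cc2cccnc2)cn1)C(C)(C)O` gives 71.5% in this assay.
Compound 3 `C[C@@H](NC(=O)c1ccc(C#Cc2ccncc2)cn1)C(C)(C)O` gives 66.6% in this assay.

Compound 1 stands lowest of the three measured numbers. Its nearest neighbour is compound 3, which lies within the scatter of it, while compound 2 lies beyond the scatter: the shift is a number 10.6 percentage points higher from compound 1 to compound 2 (beyond the scatter). Compound 3 differs from compound 1 by a number 5.7 percentage points higher from compound 1 to compound 3 (within the scatter), and compound 2 and compound 3 are within the scatter of each other, the shift being a number 4.9 percentage points lower from compound 2 to compound 3 (within the scatter).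

Compound 4 `C[C@@H](NC(=O)c1ccc(C#Cc2ncccc2F)cn1)C(C)(C)O` has not yet been measured. It differs from compound 1 in one place: 3-fluoropyridin-2-yl in place of phenyl on a triple-bonded carbon. The two steps that bear on it are those from compound 1 to compound 2 and from compound 1 to compound 3, where a nitrogen-containing six-membered ring entered in place of phenyl on the same triple-bonded carbon; one of these was modest and beyond the scatter, the other within the scatter. Within the data shown here, no measured step covers the fluorine or the 3-fluoropyridin-2-yl arrangement itself, so the expectation rests on those two ring swaps alone. Compound 4 is therefore expected to show a small rise or none beyond the scatter, estimated as a number 6.1 percentage points higher from compound 1 to compound 4 (within the scatter). Compound 4 is expected to reach 67%, within a range of 55% to 80%.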

Compound 4, largest response reached (reported as efficacy), in percent of the reference or control that the assay uses: 60.6%
Beside the measured number, compound 4's estimate is 6.4 percentage points above it; low and high end bracket the measured number.
By their numbers in this assay, from the lowest: compounds 4, 1, 3 and 2 (each within the scatter of the next, the first and the last beyond it).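

In this assay, 3-fluoropyridin-2-yl on the triple-bonded carbon gives a number 0.3 percentage points lower from compound 1 to compound 4 (within the scatter) and so, unlike pyridin-3-yl, leaves the reading within the scatter of phenyl; a ring with a hetero atom at this position therefore does not by itself set a compound apart from compound 1. Against pyridin-4-yl the change gives a number 6 percentage points lower from compound 3 to compound 4 (within the scatter) and against pyridin-3-yl it gives a number 10.9 percentage points lower from compound 2 to compound 4 (beyond the scatter), so the position does respond to which ring it carries, but among these four compounds the only steps beyond the scatter are those that involve compound 2, while compound 3 lies within the scatter of all the others. Nothing measured alongside these numbers accounts for the steps at this position.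

The change to compound 4 brings in the ring nitrogen arrangement and the fluorine together, and the compounds shown leave open what each contributes on its own. They also leave open how a ring carrying a methoxy group or an amine, or a pyrimidin-5-yl ring, would read on the same triple-bonded carbon in this assay and whether any such group would move the number beyond the scatter of compound 2.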